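One Substituent Swap on a Shared Core

The compounds below may be only part of what the source reports. "The series", "measured", "known", "first", "only" and "open" are said of these compounds alone.

Of the compounds shown here, three sharing one core have been measured in a functional assay on U2OS cells for positive allosteric modulation of metabotropic glutamate receptor 5 (Homo sapiens), read by calcium flux, in the presence of a further agent that is not named here; a higher number here means that more compound is needed for the effect, a lower number that less compound is needed. Compound 1 `CN1CCC(n2nnc3c2CCC(c2nc(-c4ccc(F)cc4)no2)C3)CC1` gives 3980 nM. Compound 2 `Fc1ccc(-c2noc(C3CCc4c(nnn4C4CCOC4)C3)n2)cc1` gives 398 nM, and compound 3 `CC(C)n1nnc2c1CCC(c1nc(-c3ccc(F)cc3)no1)C2` gives 398 nM. Compound 3 thus sits level with compound 2 and far from compound 1: a 10-fold lower number from compound 1 to compound 3 (1.00 log units; beyond the scatter), while no change at the digits printed from compound 2 to compound 3 (within the scatter). Compound 4 `CC1(n2nnc3c2CCC(c2nc(-c4ccc(F)cc4)no2)C3)CCOCC1` carries 4-methyloxan-4-yl in place of isopropyl on an aromatic nitrogen. For the measured compounds named here, the steps that bear on this change point two ways: moving to oxolan-3-yl changed nothing, whereas moving to 1-methylpiperidin-4-yl weakened the effect markedly. The new group, like oxolan-3-yl, holds an oxygen inside a ring, so only a small loss is expected, a 1.6-fold higher number from compound 3 to compound 4 (0.20 log units; within the scatter). Compound 4 is therefore estimated at 630 nM, within 200 nM to 2000 nM.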

Compound 4, half-maximal effective concentration: 10 nM
The estimate for compound 4 lay 63-fold (1.80 log units) above the measured number, outside the stated range (below it).
By their numbers in this assay, from the lowest: compound 4; then compounds 2 and 3 (each within the scatter of the next); then compound 1.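

In this assay, for the compounds shown here, the group on this aromatic nitrogen turns out to matter far more than the earlier compounds showed, with a 40-fold lower number from compound 3 to compound 4 (1.60 log units; beyond the scatter) and a 40-fold lower number from compound 2 to compound 4 (1.60 log units; beyond the scatter) as the result of one swap. Against 1-methylpiperidin-4-yl the gap widens to a 400-fold lower number from compound 1 to compound 4 (2.60 log units; beyond the scatter) and a ring oxygen alone does not settle the number, since oxolan-3-yl and 4-methyloxan-4-yl each hold one yet sit far apart. Nothing measured here accounts for this gain.

On these data alone, whether it belongs to the methyl, the six-membered ring or the ring oxygen stays open: oxan-4-yl and 1-methylcyclohexyl would separate these.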